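The compounds below may be only part of what the source reports. "The series", "measured", "known", "first", "only" and "open" are said of these compounds alone.

In a functional assay on L1210 cells (Mus musculus) for antiproliferative activity (on this read-out lower numbers stand for stronger inhibition and higher numbers for weaker inhibition), compound 1 (`COc1cc2nccc(O)c2c(O)c1OC`) gives > 40000 nM as a limit of the assay, not a number. Compound 2 (`COc1cc(O)c2c(O)ccnc2c1`) gives > 40000 nM in this assay and that too is only a limit. All the data so far come down to the limit of > 40000 nM in this assay, at which 2 of the 2 values shown sit, alone. Compound 3 (`Oc1ccnc2cc(C(F)(F)F)cc(O)c12`) differs from compound 2 in one place (trifluoromethyl in place of methoxy on an aromatic carbon) with trifluoromethyl in place of methoxy on an aromatic carbon. Within the data shown here, the one measured step (a step that the two limits leave unreadable from compound 1 to compound 2) has no readable size to carry over, so no step beyond the scatter is expected in this assay here. The expected step is a number no higher from compound 2 to compound 3 (the limit leaves the size open) by this estimate. For compound 3 the estimate is 40000 nM with an expected range of 15000 nM to 80000 nM overall.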

Compound 3, half-maximal inhibitory concentration: > 40000 nM
Compound 3 ended at the assay's limit (the forecaster's own chance of this, stated with the estimate: 75%); the middle value sits exactly at the limit.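

Among these compounds, compound 3 gives > 40000 nM in this assay, which is a limit and not a number, so no step from compound 2 to compound 3 can be read. On these data alone, whether swapping methoxy for trifluoromethyl changes inhibition at all stays open.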